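A few compounds are considered here, and "the series" means these few. Any claim that something is new, unique, unknown or untested is made for them only; others in the source may bear on it.

Values measured in a functional assay (aorta) with Rattus norvegicus as the target (on this read-out higher numbers stand for an effect only at larger amounts of compound and lower numbers for an effect already at smaller amounts), are these
- compound 1 `N#Cc1ccc2c(c1)C(N1CCCC1=O)=CC(CF)(CF)O2` gives 102 nM
- compound 2 `O=C1CCCN1C1=CC(CF)(CF)Oc2ccc([N+](=O)[O-])cc21` gives 7.76 nM
- compound 3 `O=C1CCCN1C1=CC(CF)(CF)Oc2ccc(C(F)(F)C(F)(F)F)cc21` gives 1.51 nM

Compound 1 has the highest number of the three. Compound 4 `N#Cc1ccc2c(c1)C(N1CCCCC1=O)=CC(CF)(CF)O2` keeps the cyano group and the core of compound 1 and differs in one place: 2-oxopiperidin-1-yl in place of 2-oxopyrrolidin-1-yl on a double-bonded ring carbon with 2-oxopiperidin-1-yl in place of 2-oxopyrrolidin-1-yl on a double-bonded ring carbon.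

The measured steps all lie elsewhere, on an aromatic carbon. They are a 13-fold lower number from compound 1 to compound 2 (1.12 log units; beyond the scatter) for nitro in place of cyano, a 68-fold lower number from compound 1 to compound 3 (1.83 log units; beyond the scatter) for 1,1,2,2,2-pentafluoroethyl in place of cyano, and a 5.1-fold lower number from compound 2 to compound 3 (0.71 log units; beyond the scatter) for 1,1,2,2,2-pentafluoroethyl in place of nitro. These show that one change can move the number a long way in this small set, but none varies the group that changes here, so they bear only indirectly and give no direction.

The expected step is a 1.3-fold lower number from compound 1 to compound 4 (0.11 log units; within the scatter) as an estimate, with no change beyond the scatter foreseen in this assay for this swap. Compound 4 is expected at 80 nM with a range of 25 nM to 260 nM as the estimate.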

Compound 4, half-maximal effective concentration: 162 nM
The estimate for compound 4 lay 2.0-fold (0.31 log units) below the measured number; measured number inside the range.
By their numbers in this assay, from the lowest: compound 3; then compound 2; then compounds 1 and 4 (each within the scatter of the next).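

Within the data shown here, the swap of 2-oxopyrrolidin-1-yl for 2-oxopiperidin-1-yl on the double-bonded ring carbon gives the first reading at this position in this assay, a 1.6-fold higher number from compound 1 to compound 4 (0.20 log units; within the scatter), which stays within the scatter. With the cyano group and the core of compound 1 kept, a six-membered ring in place of a five-membered one therefore leaves the number unresolved from its starting value, whereas the changes on the aromatic carbon moved it well beyond the scatter, as in a 68-fold lower number from compound 1 to compound 3 (1.83 log units; beyond the scatter). No measurement here bears on why this swap behaves as it does.

As far as these compounds go, it stays open whether 2-oxopiperidin-1-yl would read the same alongside the nitro group of compound 2 or the 1,1,2,2,2-pentafluoroethyl group of compound 3. Also open, from the compounds shown here alone, is how an open-chain acetamide or a simple amine would read at this position.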